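Trimming the Sulfur Side Chain on a Thromboxane Receptor Blocker

This account rests on a few compounds, and the source may have more. Where it says the series, first, only, none or still open, it means among the compounds named here.

Of the compounds shown here, two sharing the same core have been measured so far. Compound 1, `CSCSCC1C2CCC(O2)C1C/C=C\CCCC(=O)O`, carries a short sulfur-containing group on the saturated chain carbon bound to a sulfur; in a functional assay on a cell-free system (plasma) for inhibition of thromboxane A2 receptor (Homo sapiens) (on this read-out higher numbers stand for weaker inhibition and lower numbers for stronger inhibition), compound 1 gives 700 nM. Compound 2, `CCC/C=C(\C)CSCC1C2CCC(O2)C1C/C=C\CCCC(=O)O`, has a six-carbon chain with one double bond in that position; in this assay compound 2 gives 1100 nM. On the numbers shown, compound 2 holds the higher of the two, yet its only neighbour is compound 1, and the step of a 1.6-fold higher number from compound 1 to compound 2 (0.20 log units; within the scatter) lies within the scatter, so the two compounds are best read as alike.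

Compound 3, `CC/C=C/CCSCC1C2CCC(O2)C1C/C=C\CCCC(=O)O`, makes a further change at the same position: a group of 5 heavy atoms (5 carbon; no ring) in place of a group of 6 heavy atoms (6 carbon; no ring), on a saturated chain carbon bound to a sulfur. Within the data shown here, the only measured step that bears on this position is the one just described, and it was too small to count as a real change. Because a 1.6-fold higher number from compound 1 to compound 2 (0.20 log units; within the scatter) stayed within the scatter, no step beyond the scatter is expected for compound 3 in either direction, and the expected step is a 1.2-fold lower number from compound 2 to compound 3 (0.09 log units; within the scatter). Compound 3 is therefore estimated at 900 nM, with a range from 400 nM to 2000 nM.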

Compound 3, half-maximal inhibitory concentration: 700 nM
Compound 3: the middle estimate sits 1.3-fold (0.11 log units) above what was measured, and the stated range covers the measured number.
By their numbers in this assay, from the lowest: compounds 1, 3 and 2 (each within the scatter of the next).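

Compound 3 adds a third group at this position, and the comparison now covers more than a single pair. In this assay the step to pent-2-en-1-yl from the six-carbon chain is a 1.6-fold lower number from compound 2 to compound 3 (0.20 log units; within the scatter) and the same group in place of methylsulfanyl gives no change at the digits printed from compound 1 to compound 3 (within the scatter) so the three compounds read as alike on this saturated chain carbon bound to a sulfur, even though one group contains sulfur and the other two contain only carbon. The measured range of side chains therefore widens with no step beyond the scatter, but nothing available explains why these groups perform alike.

All three groups shown have no ring and no hydrogen-bond donors or acceptors, so it remains open whether a phenyl ring, an amine or a hydroxyl group at this position would produce a step beyond the scatter. Going by these compounds, a much longer carbon chain is equally open, and only such a group could show how far this similarity extends.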